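The source may report more compounds than this note shows. Statements on the series, on what has been measured and on what is new or still open speak of the compounds shown alone.

Among the compounds with values here, in an ADME assay on RAW264.7 cells (Mus musculus) for cytotoxicity, read by MTT assay, with a stated time of 24 h (a higher number here means that more compound is tolerated, a lower number that less compound is tolerated), compound 1 (`CC/C=C\C[C@H]1C(=O)C=C[C@H]1CC(=O)OCCOCCO`) gives 166 uM and compound 2 (`CC/C=C\C[C@H]1C(=O)C=C[C@H]1CC(=O)OCCOCCOCCO`) gives 162 uM, so compound 2 stands level with its only measured neighbour. Compound 3 (`CC/C=C\C[C@H]1C(=O)C=C[C@H]1CC(=O)OCCOC`) shares the core but carries a shorter chain: hydrogen in place of (2-hydroxyethoxy)methyl on a saturated chain carbon bound to an oxygen on a saturated carbon. Its 2-(2-hydroxyethoxy)ethoxy becomes methoxy. Within the data shown here, only one measured step bears on this change, a 1.0-fold lower number from compound 1 to compound 2 (0.01 log units; within the scatter), which also alters this chain and is very small. It does not, however, show what happens when the chain is cut back to methoxy. The expected step is therefore no larger than the scatter, a 1.1-fold lower number from compound 2 to compound 3 (0.05 log units; within the scatter). The estimate for compound 3 is 145 uM, with an expected range of 80 uM to 260 uM.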

Compound 3, half-maximal toxic concentration: 160 uM
Compound 3: the middle estimate sits 1.1-fold (0.04 log units) below what was measured; the range from low to high includes it.
By their numbers in this assay, from the lowest: compounds 3, 2 and 1 (each within the scatter of the next).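

The earlier pair showed only a 2-hydroxyethyl added to the chain end. Compound 3 shows that cutting the 2-(2-hydroxyethoxy)ethoxy back to methoxy, which also removes the chain's hydrogen-bond donor, stays within the scatter in this assay (a 1.0-fold lower number from compound 2 to compound 3 (0.01 log units; within the scatter)), and the same holds for the shorter cut (a 1.0-fold lower number from compound 1 to compound 3 (0.02 log units; within the scatter)). These three chains therefore cannot be told apart in this cell test, and no available measurement offers a reason for that. Going by these compounds, whether an amine or a carboxylic acid at the chain end, or a much longer chain, would shift the number remains open.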